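Changing the Aryl Group on the Ring Nitrogen

The compounds below may be only part of what the source reports. "The series", "measured", "known", "first", "only" and "open" are said of these compounds alone.

Three compounds have been measured in an assay on CHO-K1 cells for antagonist activity at transient receptor potential cation channel subfamily V member 1 (Homo sapiens), read by FLIPR and calcium flux, with a stated time of 6 min; on this read-out lower numbers stand for stronger inhibition and higher numbers for weaker inhibition:

compound 1, `O=C(NCc1cc(C(F)(F)F)nn1-c1ccc(Cl)cc1)Nc1cccc2[nH]ncc12`: 2.5 nM
compound 2, `Cc1ccc(-n2nc(C(F)(F)F)cc2CNC(=O)Nc2cccc3[nH]ncc23)cc1C`: 2.8 nM
compound 3, `Cn1ncc2c(NC(=O)NCc3cc(C(F)(F)F)nn3-c3ccc(Cl)cc3)cccc21`: 2.7 nM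

Compound 3 gives the second highest of the three numbers; compound 2 is nearest and compound 1 furthest, and both gaps lie within the scatter. Compound 4, `Cn1ncc2c(NC(=O)NCc3cc(C(F)(F)F)nn3-c3ccc(F)c(F)c3)cccc21`, differs from compound 3 by 3,4-difluorophenyl in place of 4-chlorophenyl on an aromatic nitrogen. Among the compounds with values here, the one measured step at that position is a 1.1-fold higher number from compound 1 to compound 2 (0.05 log units; within the scatter), which stayed within the scatter; the step of a 1.1-fold higher number from compound 1 to compound 3 (0.03 log units; within the scatter) did likewise. On that basis the step of a 1.1-fold higher number from compound 3 to compound 4 (0.05 log units; within the scatter) is expected to show no change beyond the scatter. Compound 4 is therefore estimated at 3 nM, with a range from 1.5 nM to 6.5 nM.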

Compound 4, inhibition constant: 4.9 nM
Beside the measured number, compound 4's estimate is 1.6-fold (0.21 log units) below it; the measured number falls inside the stated range.
By their numbers in this assay, from the lowest: compounds 1, 3, 2 and 4 (each within the scatter of the next).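

In this assay, 3,4-difluorophenyl in place of 4-chlorophenyl on the aromatic nitrogen gives a 1.8-fold higher number from compound 3 to compound 4 (0.26 log units; within the scatter) and so stays inside the usual variation. The position thus accepts a third aryl group, now one bearing two fluorine atoms, and it does so on the core with methyl on its aromatic nitrogen, not only on the core of compound 1. Nothing available gives a reason for the size of this step. Open remains how this position would respond to an aryl group carrying an amine or a carboxylic acid. Going by these compounds, a cyclohexyl group or a longer alkyl chain in place of the aryl group is equally open.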